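The source may hold more compounds than are shown below. What is called first, only, known or untested is meant among the compounds shown, and "the series" means these compounds.

Measured so far:
- compound 1 `C=CCc1cc(C(C)=O)c(O)cc1OCCCCCCCCC#N` — 50%
- compound 2 `CCc1cc(C(C)=O)c(O)cc1OCCCCC(C)(C)C#N` — 30%

In an assay on isolated protein for binding affinity to leukotriene B4 receptor 1 (Homo sapiens), tested at 1 uM (on this read-out higher numbers stand for more inhibition at the one concentration tested (going by the name of the read-out) and lower numbers for less inhibition), compound 1 gives 50%. This is the higher of the two numbers measured to date; compound 2 gives 30%, and the gap between the two is beyond the usual scatter of the read-out. The two compounds differ in more than one place, so the gap is not assigned to any single change.

Compound 3 `C=CCc1cc(C(C)=O)c(O)cc1OCCCCCC(C)=O` is the next compound to be measured in this assay. It differs from compound 1 in one place: acetyl in place of 3-cyanopropyl on a saturated chain carbon, five bonds along the chain from an oxygen on an aromatic ring. The chain is shortened and the nitrile gives way to a carbonyl, with the count of hydrogen-bond acceptors unchanged.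

Within the data shown here, no measured step covers this change. Among the measured compounds shown here, a modest loss is expected, a number 12 percentage points lower from compound 1 to compound 3 (beyond the scatter), reflecting that compound 2, the only other measured compound, gives 30% with a different chain end. For compound 3 the estimated value is 38%, with a likely range from 18% to 58%.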

Compound 3, a percentage reported as inhibition, at one concentration (the size of the read-out at that concentration, not a potency): 58%
Compound 3: the middle estimate sits 20 percentage points below what was measured; the range from low to high includes it.
By their numbers in this assay, from the lowest: compound 2; then compounds 1 and 3 (each within the scatter of the next).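

In this assay, among these compounds, the first single-place step reads a number 8 percentage points higher from compound 1 to compound 3 (within the scatter), for acetyl in place of 3-cyanopropyl on a saturated chain carbon, five bonds along the chain from an oxygen on an aromatic ring. The nitrile and the extra chain length of compound 1 are therefore not needed to keep this read-out: the shorter, carbonyl-ended chain of compound 3 gives 58%, level with compound 1 within the scatter. Nothing available explains why the two chain ends read alike.

On these data alone, whether a carboxylic acid or an amine at the chain end would read like acetyl remains open, as does a longer chain ending in acetyl. Compound 2 differs from compound 1 and compound 3 in more than one place, so its lower number cannot be assigned to any single group.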